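This account rests on a few compounds, and the source may have more. Where it says the series, first, only, none or still open, it means among the compounds named here.

In a functional assay on MDA-MB-231 cells (Homo sapiens) for antiproliferative activity, read by MTT assay, with a stated time of 48 h (a lower number here means a stronger inhibitor, a higher number a weaker inhibitor), compound 1 `COC(=O)/C(=C/c1ccccc1)CN1C(=O)[C@@H](OC)[C@H]1c1ccc(Cl)cc1` gives 15600 nM, compound 2 `COC(=O)/C(=C/c1ccccc1)CN1C(=O)[C@@H](OC)[C@H]1c1ccccc1C(F)(F)F` gives 17600 nM and compound 3 `CCOC(=O)/C(=C/c1ccccc1)CN1C(=O)[C@@H](OC)[C@H]1c1cccc([N+](=O)[O-])c1` gives 14400 nM. Compound 2 therefore stands level with the other two, as all three numbers lie within the usual scatter of one another. Compound 4 `COC(=O)/C(=C/c1ccccc1)CN1C(=O)[C@@H](OC)[C@H]1c1ccc(OC)cc1` differs from compound 2 in one place: 4-methoxyphenyl in place of 2-(trifluoromethyl)phenyl on a saturated ring carbon. Going by the values given here, the only measured step at this carbon, a 1.1-fold higher number from compound 1 to compound 2 (0.05 log units; within the scatter), stays within the scatter, so no step beyond the scatter is expected here, in either direction. The expected step is a 1.3-fold lower number from compound 2 to compound 4 (0.10 log units; within the scatter). For compound 4 the estimated value is 14000 nM, with an expected range from 6000 nM to 28000 nM.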

Compound 4, half-maximal inhibitory concentration: 14000 nM
For compound 4 middle estimate and measured number coincide at the digits printed; measured number inside the range.
By their numbers in this assay, from the lowest: compounds 4, 3, 1 and 2 (each within the scatter of the next).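

In this assay, 4-methoxyphenyl on this saturated ring carbon gives a 1.3-fold lower number from compound 2 to compound 4 (0.10 log units; within the scatter), so a second change at this carbon also stays within the scatter. Changing only the group on the aromatic carbon, methoxy in place of chloro, gives a 1.1-fold lower number from compound 1 to compound 4 (0.05 log units; within the scatter), which is likewise within the scatter. Nothing available explains why these numbers stay so close. Still open, as far as these compounds go, is whether an amine or a carboxylic acid on this aromatic ring would produce a step beyond the scatter. Also open, from the compounds shown here alone, is whether replacing the whole aromatic ring at this carbon with a longer chain would do so.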